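The source may hold more compounds than are shown below. What is called first, only, known or untested is meant among the compounds shown, and "the series" means these compounds.

Measured in a functional assay on MGC-803 cells (Homo sapiens) for antiproliferative activity, read by MTT assay, with a stated time of 48 h; on this read-out lower numbers stand for stronger inhibition and higher numbers for weaker inhibition:
- Compound 1 `COc1ccc(CN(C(=O)CSc2nc3ccccc3s2)c2cc(OC)c(OC)c(OC)c2)cc1C`: 6360 nM
- Compound 2 `COc1cc(N(Cc2ccc(Cl)cc2)C(=O)CSc2nc3ccccc3s2)cc(OC)c1OC`: > 80000 nM (a limit of the assay, not a number)

Compound 2 stands at the limit of > 80000 nM in this assay, at which 1 of the 2 values shown sits, so it has no exact number and is the weaker of the two compounds. Compound 3 `COc1ccc(CN(C(=O)CSc2nc3ccccc3s2)c2cc(OC)c(OC)c(OC)c2)cc1F` carries 3-fluoro-4-methoxyphenyl in place of 4-chlorophenyl on a saturated chain carbon bound to an amide-type nitrogen.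

Among the measured compounds shown here, one measured step bears on this change, at the same place: an at least 12-fold higher number from compound 1 to compound 2 (1.09 log units; beyond the scatter). That step was large and lay beyond the scatter. The new group shares its methoxy with the 4-methoxy-3-methylphenyl of compound 1, and it also removes the 4-chlorophenyl that came with the loss. The expectation therefore leans toward compound 1, at 6360 nM. For the measured compounds named here, no measured compound shows what the fluorine does on its own, so the range stays wide.

A large move toward lower numbers is expected, with an at least 10-fold lower number from compound 2 to compound 3 (1.00 log units; beyond the scatter) as the estimated step. For compound 3 the estimate is 8000 nM, with an expected range of 2000 nM to 32000 nM.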

Compound 3, half-maximal inhibitory concentration: 416 nM
For compound 3 the middle estimate is 19-fold (1.28 log units) above the measured one; measured number below the stated range.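

In this assay, this place on the saturated chain carbon bound to an amide-type nitrogen proves sensitive to more than the presence of a methoxy group, since compound 1 and compound 3 both carry one, yet fluoro in place of methyl on an aromatic carbon gives a 15-fold lower number from compound 1 to compound 3 (1.18 log units; beyond the scatter). Replacing 4-chlorophenyl with 3-fluoro-4-methoxyphenyl gives a still wider gap, an at least 190-fold lower number from compound 2 to compound 3 (2.28 log units; beyond the scatter), so the benzyl group on the amide-type nitrogen can carry the activity of this series from the weakest reading shown to the strongest. Compound 2 has a limit of the assay and not a number, which leaves the true size of that gap open: the limit of > 80000 nM in this assay, at which 1 of the 3 values shown sits.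

The compounds shown do not separate what the fluoro and the methoxy each contribute, and a plain 4-methoxyphenyl or a 3-fluorophenyl would be needed to tell them apart. Going by these compounds, it also remains open whether the low number survives with chloro, a nitrile or an amine in place of the fluoro, or with an ethoxy in place of the methoxy.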